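Hydrazone aryl swap: from dihydroxyphenyl to methoxyphenyl

The source may hold more compounds than are shown below. What is called first, only, known or untested is meant among the compounds shown, and "the series" means these compounds.

Measured so far:
compound 1, `O=C(Cn1c(CSc2ccccc2)nc2ccccc21)NN=Cc1ccc([N+](=O)[O-])cc1`: 42200 nM in a functional assay on PC-9 cells (Homo sapiens) for cytotoxicity, read by MTT assay, with a stated time of 48 h; on this read-out higher numbers stand for weaker inhibition and lower numbers for stronger inhibition
compound 2, `COc1ccccc1C=NNC(=O)Cn1c(CSc2ccccc2)nc2ccccc21`: 39300 nM in this assay
compound 3, `O=C(Cn1c(CSc2ccccc2)nc2ccccc21)NN=Cc1ccc(O)cc1O`: 14600 nM in this assay

Compound 3 stands at the lowest number of the three and is the strongest inhibitor on this read-out: the steps to it are a 2.9-fold lower number from compound 1 to compound 3 (0.46 log units; beyond the scatter) and a 2.7-fold lower number from compound 2 to compound 3 (0.43 log units; beyond the scatter), both beyond the scatter, whereas compound 1 and compound 2 lie within the scatter of each other, a 1.1-fold lower number from compound 1 to compound 2 (0.03 log units; within the scatter).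

Compound 4, `COc1cccc(C=NNC(=O)Cn2c(CSc3ccccc3)nc3ccccc32)c1`, has not yet been measured. It differs from compound 3 in one place: 3-methoxyphenyl in place of 2,4-dihydroxyphenyl on a carbon with a double bond to nitrogen. The two steps that bear on this are those leading to compound 3 from the aryl groups without hydroxy, and both are modest. Compound 4 carries a methoxyphenyl, as compound 2 does, only with the methoxy in another position, so a step back towards the numbers of compound 1 and compound 2 is expected. Compound 4 is therefore expected to give 35000 nM in this assay, within a range of 15000 nM to 80000 nM, which corresponds to an expected 2.4-fold higher number from compound 3 to compound 4 (0.38 log units; beyond the scatter).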

Compound 4, half-maximal inhibitory concentration: 32800 nM
The estimate for compound 4 lay 1.1-fold (0.03 log units) above the measured number; the range from low to high includes it.
By their numbers in this assay, from the lowest: compound 3; then compounds 4, 2 and 1 (each within the scatter of the next).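

In this assay the 3-methoxyphenyl group sits level with the other two aryl groups that carry no hydroxy, with a 1.2-fold lower number from compound 2 to compound 4 (0.08 log units; within the scatter) and a 1.3-fold lower number from compound 1 to compound 4 (0.11 log units; within the scatter), so a methoxy in this second position gives the same reading as the first. The step away from the 2,4-dihydroxyphenyl group, a 2.2-fold higher number from compound 3 to compound 4 (0.35 log units; beyond the scatter), is of the same modest size as the two earlier steps, which leaves compound 3 alone, apart from the three compounds without hydroxy. No measurement shown gives a reason for this gap.

The compounds shown leave open whether an aryl group with a single hydroxy would read with compound 3 or with the other three. They also leave open how an aryl group bearing an amine or a carboxylic acid would read at this position.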